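Bromo in place of methoxy: compound 3 to compound 4

This account rests on a few compounds, and the source may have more. Where it says the series, first, only, none or still open, it means among the compounds named here.

In a functional assay on A549 cells (Homo sapiens) for inhibition, read by MTT assay, with a stated time of 24 h (a lower number here means a stronger inhibitor of growth, a higher number a weaker inhibitor of growth), compound 1 (`COc1ccc(C(=O)n2c(-c3cn(C)c4ccccc34)nc3ccccc32)cc1`) gives 10400 nM as its value, compound 2 (`COc1ccc2c(c1)c(-c1nc3ccccc3n1C(=O)c1ccc(OC)c(OC)c1)cn2C`) gives 2700 nM and compound 3 (`COc1ccc2c(c1)c(-c1nc3ccccc3n1C(=O)c1cc(OC)c(OC)c(OC)c1)cn2C`) gives 2400 nM and sits with compound 2 within the scatter, both lower than compound 1. Compound 4 (`COc1cc(C(=O)n2c(-c3cn(C)c4ccc(Br)cc34)nc3ccccc32)cc(OC)c1OC`) has bromo in place of methoxy on an aromatic carbon. Going by the values given here, the one measured step (a 1.1-fold lower number from compound 2 to compound 3 (0.05 log units; within the scatter)) is a methoxy change elsewhere in the molecule and says nothing directly about this carbon. Among the compounds with values here, compound 1 lacks that methoxy but also differs in a further place, so no measured pair isolates it. No step beyond the scatter is expected in this assay and the estimated size is a 1.3-fold higher number from compound 3 to compound 4 (0.10 log units; within the scatter) with wide uncertainty. For compound 4 the estimated value is 3000 nM within a range of 1000 nM to 9000 nM as the expected span.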

Compound 4, concentration for 50% growth inhibition: 3000 nM
Compound 4: the middle estimate sits on the measured number at the digits printed; measured number inside the range.
By their numbers in this assay, from the lowest: compounds 3, 2 and 4 (each within the scatter of the next); then compound 1.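

In this assay, bromo in place of methoxy on this aromatic carbon gives a 1.3-fold higher number from compound 3 to compound 4 (0.10 log units; within the scatter), within the scatter. At this position, a single bromine atom can therefore stand in place of the methoxy without a change that can be read in this assay. No evidence on the cause of this result is available. Still open, on these data alone, is how an amine or a carboxylic acid on this carbon would read in this assay. Also open, as far as these compounds go, is the effect of hydrogen here with the rest of compound 4 unchanged.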